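Series notes: aryl swap at the core of compound 2

The compounds below may be only part of what the source reports. "The series", "measured", "known", "first", "only" and "open" are said of these compounds alone.

Compound 2 `Cc1cccc(-c2cc(-c3ccc(Cl)o3)cc(-c3ccsc3)n2)c1` is measured in an assay on isolated protein for inhibition of DNA topoisomerase 1 (Homo sapiens), tested at 100 uM (on this read-out higher numbers stand for a stronger effect at the one concentration tested and lower numbers for a weaker effect), and gives 7.5%. Compound 1 `Clc1ccc(-c2cc(-c3ccoc3)cc(-c3cccs3)n2)cc1` gives 0%, and compound 3 `Clc1ccc(-c2cc(-c3ccco3)cc(-c3cccs3)n2)cc1` gives 2.7%. Of the three numbers, that of compound 2 is the largest, but its gap to compound 3 and its gap to compound 1 both lie within the usual scatter, so no order among the three can be read from them.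

Compound 4 `Cc1ccc(-c2cc(-c3ccc(Cl)o3)cc(-c3ccsc3)n2)cc1` has not yet been measured in this assay. It differs from compound 2 in one place: 4-methylphenyl in place of 3-methylphenyl on an aromatic carbon. Among the measured compounds shown here, the only measured step, a number 2.7 percentage points higher from compound 1 to compound 3 (within the scatter), concerns a different change at a different group and is itself within the scatter; it neither supports nor contradicts an effect of the present change. For the measured compounds named here, no measured pair shows what exchanging 3-methylphenyl for 4-methylphenyl does here.

With nothing in the measured steps pointing either way, the expectation for compound 4 is a step of a number 0.5 percentage points lower from compound 2 to compound 4 (within the scatter) from compound 2, that is, no change beyond the scatter. Compound 4 is therefore estimated at 7% in this assay, within a range from 0% to 17%.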

Compound 4, a percentage reported as inhibition, at one concentration (the size of the read-out at that concentration, not a potency): 2.6%
Compound 4: middle estimate off by 4.4 percentage points, on the high side, within the range that was stated.
By their numbers in this assay, from the lowest: compounds 1, 4, 3 and 2 (each within the scatter of the next).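

Among the compounds shown here, replacing 3-methylphenyl with 4-methylphenyl on the aromatic carbon next to the ring nitrogen gives the first measured step at this position in this assay: a number 4.9 percentage points lower from compound 2 to compound 4 (within the scatter). The step shows that, for this pair, moving the methyl group around the phenyl ring does not separate the two compounds on this read-out, so compound 2 and compound 4 cannot be ranked, and the change shows no effect that can be told from the scatter. Nothing measured on these compounds bears on why the two numbers differ as they do, and no explanation can be attached to this small step.

For the compounds shown here, the step covers only one exchange between two methylphenyl groups, on a single pair with the 5-chlorofuran-2-yl and thiophen-3-yl groups in place, so it remains open whether the same holds with other groups elsewhere on the core. From the compounds shown here alone, it also remains open whether a more different group at this position, such as an amine or a carboxylic acid on the phenyl ring or a longer chain in place of the methyl, would move the read-out beyond the scatter.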